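Aryl substituent changes in a cytotoxicity series

A few compounds are considered here, and "the series" means these few. Any claim that something is new, unique, unknown or untested is made for them only; others in the source may bear on it.

Three compounds share one core and differ only in the aryl group on the double-bonded chain carbon. Compound 1 `Cc1ccc(/C=C/C[C@H]2C[C@@H]([C@@H](O)c3ccccc3)CO[C@@H]2c2ccccc2)cc1C` gives 10000 nM in a functional assay on HeLa cells (Homo sapiens) for cytotoxicity, read by WST assay, with a stated time of 48 h; a higher number here means a weaker inhibitor, a lower number a stronger inhibitor. Compound 2 `COc1ccc(/C=C/C[C@H]2C[C@@H]([C@@H](O)c3ccccc3)CO[C@@H]2c2ccccc2)cc1` gives 8300 nM in this assay, and compound 3 `Oc1cccc(/C=C/C[C@H]2C[C@@H]([C@@H](O)c3ccccc3)CO[C@@H]2c2ccccc2)c1` gives 18600 nM. Compound 3 stands highest of the three numbers; the step of a 1.9-fold higher number from compound 1 to compound 3 (0.27 log units; within the scatter) is within the scatter, whereas the step of a 2.2-fold higher number from compound 2 to compound 3 (0.35 log units; beyond the scatter) is beyond it, though modest. The step of a 1.2-fold lower number from compound 1 to compound 2 (0.08 log units; within the scatter) is within the scatter.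

Compound 4 `O[C@@H](c1ccccc1)[C@H]1CO[C@H](c2ccccc2)[C@@H](C/C=C/c2cccc(F)c2)C1` is not yet measured. It differs from compound 3 in one place: fluoro in place of hydroxy on an aromatic carbon. Within the data shown here, no measured step replaces hydroxy by fluoro, so the prior steps bear on it only loosely: all three aryl changes moved this assay by small amounts, and the only step beyond the scatter was the one that introduced hydroxy. A modest lowering of the number is therefore expected, about a 1.7-fold lower number from compound 3 to compound 4 (0.23 log units; within the scatter), because in compound 2 the aryl without hydroxy gave 8300 nM. Compound 4 is expected to give about 11000 nM in this assay, in the range 5000 nM to 25000 nM.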

Compound 4, half-maximal inhibitory concentration: 8380 nM
Estimate against measurement, compound 4: 1.3-fold (0.12 log units) above; measured number inside the range.
By their numbers in this assay, from the lowest: compounds 2, 4, 1 and 3 (each within the scatter of the next, the first and the last beyond it).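

Notes on the aromatic carbon meta to a large group: fluoro in place of hydroxy gives a 2.2-fold lower number from compound 3 to compound 4 (0.35 log units; beyond the scatter), the first direct comparison at this carbon in this assay, and the step is modest. Compound 4 sits level with the other aryl variants, at a 1.0-fold higher number from compound 2 to compound 4 (0.00 log units; within the scatter) and a 1.2-fold lower number from compound 1 to compound 4 (0.08 log units; within the scatter), so only compound 3 stands apart from compounds 2 and 4, while compound 1 remains within the scatter of compound 3. Nothing available explains why hydroxy and fluoro differ at this carbon.

The compounds shown leave open how an amine or a carboxylic acid on this same aromatic carbon would compare with hydroxy and fluoro. They also leave open whether a longer chain in place of the 3-(3-fluorophenyl)prop-2-en-1-yl group would give a step larger than these modest ones.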